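The source may hold more compounds than are shown below. What is called first, only, known or untested is meant among the compounds shown, and "the series" means these compounds.

Compound 1 `CC1(C)N=C(N)N=C(N)N1c1ccc(OCC(=O)Nc2ccc(S(=O)(=O)F)cc2)c(Cl)c1` and compound 2 `CN(C(=O)COc1ccc(N2C(N)=NC(N)=NC2(C)C)cc1Cl)c1ccc(S(=O)(=O)F)cc1` share a core and were both measured in an assay on isolated protein for inhibition of Dihydrofolate reductase (Mus musculus); on this read-out lower numbers stand for lower potency and higher numbers for higher potency (the scale is a negative logarithm). In this assay, within the data shown here, compound 1 gives 7.43, and compound 2 gives 7.47; the two numbers lie within the scatter of each other, so neither stands apart, and the step of a number 0.04 log units higher from compound 1 to compound 2 (within the scatter) is the only measured step. Compound 3 `CC1(C)N=C(N)N=C(N)N1c1cc(Cl)c(OCC(=O)Nc2ccc(S(=O)(=O)F)cc2)c(Cl)c1` has not been measured yet. It differs from compound 1 by chloro in place of hydrogen on an aromatic carbon. Among the measured compounds shown here, the one measured step concerns a methyl in place of hydrogen on an amide-type nitrogen and does not touch the aromatic ring, so no measured step bears on this change. For the measured compounds named here, the expected step is a number 0.07 log units higher from compound 1 to compound 3 (within the scatter), with no measured step to support it beyond the shared core. Compound 3 is therefore estimated at 7.5, with a range from 6.9 to 8.1.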

Compound 3, logarithm of the reciprocal of the active concentration, log(1/C): 7.74
Beside the measured number, compound 3's estimate is 0.24 log units below it, and the stated range covers the measured number.
By their numbers in this assay, from the lowest: compounds 1, 2 and 3 (each within the scatter of the next, the first and the last beyond it).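

With this change, a number 0.31 log units higher from compound 1 to compound 3 (beyond the scatter) in this assay, the series shows its first step beyond the scatter, though a modest one, whereas the methyl on the amide-type nitrogen had given none. It shows that this aromatic carbon, ortho to a large group and meta to a chloro group, takes a chloro group in place of hydrogen with a gain rather than a loss on this read-out. No evidence at hand bears on the reason for this step.

At this position the compounds shown carry only hydrogen or chloro, so it stays open whether a fluoro, bromo, methyl or methoxy group would give a similar step. Going by these compounds, it also stays open whether the chloro step would hold with the methyl of compound 2 on the amide-type nitrogen.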